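Para Methoxy on the Carbamate Aryl Ring of a Selenocyanate

The source may hold more compounds than are shown below. What is called first, only, known or untested is meant among the compounds shown, and "the series" means these compounds.

Compound 1, `N#C[Se]c1ccc(NC(=O)Oc2ccc(F)cc2)cc1`, in an ADME assay on BEAS-2B cells (Homo sapiens) for cytotoxicity, read by MTT assay, with a stated time of 72 h (a higher number here means a weaker inhibitor of growth, a lower number a stronger inhibitor of growth), gives 19800 nM.
Compound 2, `CCCOC(=O)Nc1ccc([Se]C#N)cc1`, in this assay gives 19200 nM.
Compound 3, `N#C[Se]c1ccc(NC(=O)Oc2ccccc2)cc1`, in this assay gives 8900 nM.

Compound 3 stands lowest of the three numbers; both steps to it, a 2.2-fold lower number from compound 2 to compound 3 (0.33 log units; beyond the scatter) and a 2.2-fold lower number from compound 1 to compound 3 (0.35 log units; beyond the scatter), lie beyond the scatter, so compound 3 is the strongest inhibitor of growth among the measured set.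

Compound 4, `COc1ccc(OC(=O)Nc2ccc([Se]C#N)cc2)cc1`, differs from compound 3 by methoxy in place of hydrogen on an aromatic carbon. The step that bears most on this change is a 2.2-fold lower number from compound 1 to compound 3 (0.35 log units; beyond the scatter), where a substituent was taken off the same aromatic carbon and the number fell modestly; the new change puts a substituent back onto that carbon, so the number is expected to move modestly the other way. The step of a 2.2-fold lower number from compound 2 to compound 3 (0.33 log units; beyond the scatter) concerns the oxygen-bound group and says little about a methoxy on the ring. Compound 4 is therefore expected to show a modest rise, a 1.5-fold higher number from compound 3 to compound 4 (0.16 log units; within the scatter), in this assay. The estimate for compound 4 is 13000 nM, with a range from 6000 nM to 28000 nM.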

Compound 4, concentration for 50% growth inhibition: 25200 nM
Estimate against measurement, compound 4: 1.9-fold (0.29 log units) below; measured number inside the range.
By their numbers in this assay, from the lowest: compound 3; then compounds 2, 1 and 4 (each within the scatter of the next).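

In this assay methoxy on this aromatic carbon, para to a large group, gives a 2.8-fold higher number from compound 3 to compound 4 (0.45 log units; beyond the scatter) and so lies beyond the scatter, in the same direction as the earlier step between hydrogen and fluoro. Compound 3 now stands apart from both ring-substituted compounds, so the higher number no longer rests on fluoro alone, while the exchange of one substituent for the other gives a 1.3-fold higher number from compound 1 to compound 4 (0.10 log units; within the scatter) and stays within the scatter, which means that fluoro and methoxy cannot be told apart at this position in these data. No measurement at hand offers an explanation for this result and the comparison therefore stays descriptive, resting on hydrogen against a substituent at one place on the ring.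

The compounds shown hold only hydrogen, fluoro and methoxy on this carbon, so it remains open whether an amine, a carboxylic acid or a chlorine atom there would also stand on the higher side of compound 3. On these data alone, it also remains open whether a longer chain on the same oxygen as the methoxy would carry the number further or leave it where compound 4 and compound 1 stand.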